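Phenyl for Ethyl on the Ring Nitrogen of Compound 2

The source may hold more compounds than are shown below. What is called first, only, known or untested is meant among the compounds shown, and "the series" means these compounds.

Measured compounds:
Compound 1, `Nc1ccc(CNC(=O)CC2c3ccccc3N=C(N3CCCCC3)N2c2ccccc2)cc1`, gives 33900 nM in a functional assay on HCT-15 cells (Homo sapiens) for inhibition, read by sulforhodamine B assay; on this read-out higher numbers stand for weaker inhibition of growth and lower numbers for stronger inhibition of growth.
Compound 2, `CCN1C(N2CCCCC2)=Nc2ccccc2C1CC(=O)NCc1ccc(NS(=O)(=O)c2ccc(C)cc2)cc1`, gives 25700 nM in this assay.

Compound 2 has the lower of the two numbers in this assay, but the gap to compound 1 lies within the scatter, so no order between them can be read. Compound 3, `Cc1ccc(S(=O)(=O)Nc2ccc(CNC(=O)CC3c4ccccc4N=C(N4CCCCC4)N3c3ccccc3)cc2)cc1`, is not yet measured. It differs from compound 2 in one place: phenyl in place of ethyl on an amine nitrogen in a ring. Compound 1 already carries a phenyl on this ring nitrogen and sits close to compound 2 in this assay, which suggests the exchange changes little here. The step from compound 2 to compound 3 in this assay is therefore expected to be a 1.2-fold higher number from compound 2 to compound 3 (0.07 log units; within the scatter), no shift beyond the scatter in either direction. Compound 3 is estimated at 30000 nM, with a range from 10000 nM to 90000 nM.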

Compound 3, concentration for 50% growth inhibition: 2800 nM
Estimate against measurement, compound 3: 11-fold (1.03 log units) above; the whole stated range lies above it.
By their numbers in this assay, from the lowest: compound 3; then compounds 2 and 1 (each within the scatter of the next).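

In this assay the ring nitrogen proves sensitive to this exchange once the (4-methylphenyl)sulfonyl group is present: phenyl in place of ethyl gives a clear step (a 9.2-fold lower number from compound 2 to compound 3 (0.96 log units; beyond the scatter)), which the two earlier compounds could not show. The phenyl on this nitrogen does not suffice on its own, since (4-methylphenyl)sulfonyl in place of hydrogen on a nitrogen on an aromatic ring, with that phenyl kept, gives a step of similar size (a 12-fold lower number from compound 1 to compound 3 (1.08 log units; beyond the scatter)), so compound 3 owes its low number to the two groups together. Nothing given here explains this step.

On these data alone, whether the exchange would move the number with only hydrogen on the aromatic nitrogen remains open. So does how a benzyl or a cyclohexyl on the ring nitrogen would compare with phenyl.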